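Working notes: 2-methylphenyl to 4-ethylphenyl exchange on the shared core

The compounds below may be only part of what the source reports. "The series", "measured", "known", "first", "only" and "open" are said of these compounds alone.

Measured so far in a functional assay on HCT-8 cells (Homo sapiens) for cytotoxicity; on this read-out lower numbers stand for an effect already at smaller amounts and higher numbers for an effect only at larger amounts of compound:
- compound 1 `COC1=C(C)C(=O)/C(=C(O)/C=C/c2ccc(OC)cc2)C(=O)C1(C)C`: 5.6 ug/mL
- compound 2 `COC1=C(C)C(=O)/C(=C(O)/C=C/c2ccccc2C)C(=O)C1(C)C`: 4 ug/mL

Compound 2 stands within the scatter of compound 1, so the two values set no order within this small set. Going by the values given here, the only measured step is a 1.4-fold lower number from compound 1 to compound 2 (0.15 log units; within the scatter). It exchanges the group on a double-bonded chain carbon bound to a double-bonded chain carbon, the same place that changes next.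

The next structure is compound 3 `CCc1ccc(/C=C/C(O)=C2/C(=O)C(C)=C(OC)C(C)(C)C2=O)cc1`, and the change is 4-ethylphenyl in place of 2-methylphenyl on a double-bonded chain carbon bound to a double-bonded chain carbon. Among the compounds with values here, no measured compound carries the 4-ethylphenyl group, so the data offer no direct precedent for it. Within the data shown here, the one measured step gives modest support: replacing 4-methoxyphenyl with 2-methylphenyl left this assay within the scatter, at a 1.4-fold lower number from compound 1 to compound 2 (0.15 log units; within the scatter). On that single step, no change beyond the scatter is expected, and neither direction is favoured. The expected step is a 1.1-fold higher number from compound 2 to compound 3 (0.05 log units; within the scatter). The estimated value for compound 3 is 4.5 ug/mL, with an expected range from 2 ug/mL to 10 ug/mL.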

Compound 3, concentration for half-maximal effect: 10.5 ug/mL
Compound 3: the middle estimate sits 2.3-fold (0.37 log units) below what was measured, and the stated range ends below it.
By their numbers in this assay, from the lowest: compounds 2, 1 and 3 (each within the scatter of the next, the first and the last beyond it).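

Working notes, continued. In this assay, going by these compounds alone, the group on a double-bonded chain carbon bound to a double-bonded chain carbon now shows that an exchange here can move the number beyond the scatter: 4-ethylphenyl in place of 2-methylphenyl gives the first such step (a 2.6-fold higher number from compound 2 to compound 3 (0.42 log units; beyond the scatter)). The same position does not separate every pair, since ethyl in place of methoxy on an aromatic carbon stays within the scatter (a 1.9-fold higher number from compound 1 to compound 3 (0.27 log units; within the scatter)), so the 4-ethylphenyl and 4-methoxyphenyl compounds are not told apart and only the contrast between compound 2 and compound 3 stands as a real difference. Nothing at hand bears on the reason for this step.

The compounds shown leave open whether the step between compound 2 and compound 3 follows the change from methyl to ethyl or the different place of the group on the phenyl ring, and a 4-methylphenyl or 2-ethylphenyl group would separate the two readings. They also leave open how this position responds to a phenyl ring carrying an amine or a carboxylic acid, or to a longer alkyl chain such as butyl.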